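The source may report more compounds than this note shows. Statements on the series, on what has been measured and on what is new or still open speak of the compounds shown alone.

Compounds measured:

compound 1, `Cn1c(=O)c(S(=O)(=O)c2ccc(O)cc2)cc2cnc(Nc3ccc4[nH]ccc4c3)nc21`: 100 nM
compound 2, `Cn1c(=O)c(S(=O)(=O)c2ccccc2)cc2cnc(Nc3cnc4[nH]ccc4c3)nc21`: 5000 nM
compound 3, `Cn1c(=O)c(S(=O)(=O)c2ccc(Cl)cc2)cc2cnc(Nc3cccc4[nH]ccc34)nc21`: 5000 nM

In a functional assay on K562 cells (Homo sapiens) for inhibition, read by trypan blue exclusion, with a stated time of 72 h (a higher number here means a weaker inhibitor, a lower number a stronger inhibitor), compound 1 holds the lowest number of the three, with compound 2 and compound 3 both far higher, well beyond the scatter. Within the data shown here, none of these three pairs differs in only one place, so the numbers show only that compound 1 is the strongest inhibitor of the set.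

Among the measured compounds shown here, compound 4, `Cn1c(=O)c(S(=O)(=O)c2ccc(Br)cc2)cc2cnc(Nc3ccc4[nH]ccc4c3)nc21`, is the one change from compound 1: bromo in place of hydroxy on an aromatic carbon. For the measured compounds named here, there is no directly comparable pair to lean on, so the step from compound 1 to compound 4 in this assay is expected to be a modest weakening, about a 3.0-fold higher number from compound 1 to compound 4 (0.48 log units; beyond the scatter), with wide uncertainty. Compound 4 is estimated at 300 nM, within a range of 80 nM to 1500 nM.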

Compound 4, half-maximal inhibitory concentration: 5000 nM
Estimate against measurement, compound 4: 17-fold (1.22 log units) below, outside the stated range (above it).
By their numbers in this assay, from the lowest: compound 1; then compounds 2, 3 and 4 (each within the scatter of the next).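

Among these compounds, replacing hydroxy with bromo on the aromatic carbon is the first single change in this set, and in this assay it gives a large loss (a 50-fold higher number from compound 1 to compound 4 (1.70 log units; beyond the scatter)). The position therefore responds strongly to what it carries: with the rest of compound 1 unchanged, hydroxy gives the stronger inhibitor of the two. No evidence here bears on the reason for this loss.

As far as these compounds go, whether an amine, a methoxy group or a carboxylic acid at this position could match hydroxy remains open. Only these two groups can be compared here.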